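A few compounds are considered here, and "the series" means these few. Any claim that something is new, unique, unknown or untested is made for them only; others in the source may bear on it.

Going by the values given here, in a functional assay on K562 cells (Homo sapiens) for cytotoxicity, read by MTT assay (on this read-out higher numbers stand for weaker inhibition and lower numbers for stronger inhibition), compound 2 `CC1=CCC[C@H]2[C@](C)(CC3=CC(=O)C=CC3=O)[C@@H](C)CC[C@]12C` gives 4900 nM, the only actual number available so far. Compound 1 `CCCCCCCCSC1=CC(=O)C(C[C@]2(C)[C@@H](C)CC[C@]3(C)C(C)=CCC[C@@H]23)=CC1=O` reaches only a limit, > 100000 nM. Compound 3 `CCCSC1=CC(=O)C(C[C@]2(C)[C@@H](C)CC[C@]3(C)C(C)=CCC[C@@H]23)=CC1=O` is the next to be considered, and it differs from compound 2 by propylsulfanyl in place of hydrogen on a double-bonded ring carbon, with propylsulfanyl in place of hydrogen on a double-bonded ring carbon. Among the compounds with values here, the one measured step that bears on this is an at least 20-fold lower number from compound 1 to compound 2 (1.30 log units; beyond the scatter), where hydrogen replaces octylsulfanyl on a double-bonded ring carbon. Read in reverse, that large step points towards a higher number in this assay once a sulfanyl chain is present, although propylsulfanyl itself has not been tested. A rise beyond the scatter is therefore expected, an estimated 3.1-fold higher number from compound 2 to compound 3 (0.49 log units; beyond the scatter). For compound 3 the expected value is 15000 nM, with an estimated range from 4000 nM to 60000 nM.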

Compound 3, half-maximal inhibitory concentration: 45500 nM
The estimate for compound 3 lay 3.0-fold (0.48 log units) below the measured number, within the range that was stated.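

At this position, on a double-bonded ring carbon of a six-membered non-aromatic ring of carbon only, even the short propylsulfanyl chain weakens the result in this assay, with a 9.3-fold higher number from compound 2 to compound 3 (0.97 log units; beyond the scatter). Chain length on the sulfur also counts, since shortening octylsulfanyl to propylsulfanyl gives an at least 2.1-fold lower number from compound 1 to compound 3 (0.34 log units; beyond the scatter), so the presence of a sulfanyl group is not the whole of the change. Compound 1 stands only at a limit, so the full size of that second step cannot be read: the limit of > 100000 nM in this assay, at which 1 of the 3 values shown sits.

Whether the number climbs evenly with chain length stays open, as only hydrogen, propylsulfanyl and octylsulfanyl are shown here. From the compounds shown here alone, it is also open whether methylsulfanyl, or a propylsulfanyl chain ending in an amine or a carboxylic acid, would stay closer to compound 2.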